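From a Dimethylaminophenyl to a Benzyl Group

The source may hold more compounds than are shown below. What is called first, only, known or untested is meant among the compounds shown, and "the series" means these compounds.

Among the measured compounds shown here, compound 2 `CC(C(=O)NCc1ccc(C(F)(F)F)nc1-c1ccc(N(C)C)cc1)c1ccc(NS(C)(=O)=O)c(F)c1` shows the lower of the two numbers measured so far in an assay on CHO cells for antagonist activity at transient receptor potential cation channel subfamily V member 1 (Homo sapiens), read by FLIPR (a higher number here means a weaker inhibitor, a lower number a stronger inhibitor), giving 3.2 nM, but its gap to compound 1 `CC(C(=O)NCc1ccc(C(F)(F)F)nc1-c1ccccc1)c1ccc(NS(C)(=O)=O)c(F)c1`, which gives 6.4 nM, falls within the scatter: the step of a 2.0-fold lower number from compound 1 to compound 2 (0.30 log units; within the scatter) changed little. Compound 3 `CC(C(=O)NCc1ccc(C(F)(F)F)nc1Cc1ccccc1)c1ccc(NS(C)(=O)=O)c(F)c1` differs from compound 2 by benzyl in place of 4-(dimethylamino)phenyl on an aromatic carbon. For the measured compounds named here, that single earlier step is the only one touching this position, and no measured step replaces the whole aromatic group with a benzyl, so the direction is uncertain; a modest loss is expected, a 3.1-fold higher number from compound 2 to compound 3 (0.49 log units; beyond the scatter). Compound 3 is therefore estimated at 10 nM, between 3 nM and 40 nM.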

Compound 3, inhibition constant: 141 nM
Compound 3: middle estimate off by 14-fold (1.15 log units), on the low side, outside the stated range (above it).
By their numbers in this assay, from the lowest: compounds 2 and 1 (each within the scatter of the next); then compound 3.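

In this assay, the position next to the ring nitrogen responds sharply to benzyl: replacing 4-(dimethylamino)phenyl with it gives (a 44-fold higher number from compound 2 to compound 3 (1.64 log units; beyond the scatter)), and replacing the plain phenyl gives (a 22-fold higher number from compound 1 to compound 3 (1.34 log units; beyond the scatter)). Adding dimethylamino to the phenyl ring had stayed within the scatter, so this position is not indifferent to every change. Nothing measured here explains the loss. The compounds shown leave open whether the loss is specific to benzyl or extends to other groups at this position. A phenethyl chain or a cyclohexyl ring would help to answer this.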